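Swapping the Triazole Attachment Point on a Seven-Carbon Linker

The source may hold more compounds than are shown below. What is called first, only, known or untested is meant among the compounds shown, and "the series" means these compounds.

Three compounds sharing a biphenyl-triazole head and a seven-carbon linker to a pyridinyl-triazole tail have been measured in a functional assay on SH-SY5Y cells (Homo sapiens) for cytotoxicity, read by MTT assay, with a stated time of 56 h; a lower number here means that less compound is needed, a higher number that more compound is needed for the effect. Compound 1 `c1ccc(-c2ccccc2-c2cn(CCCCCCCn3cc(-c4cccnc4)nn3)nn2)cc1` gives 9.1 nM. Compound 2 `c1ccc(-c2ccccc2-c2cn(CCCCCCCc3cn(-c4cccnc4)nn3)nn2)cc1` gives 84.2 nM. The two differ only in the way the tail is attached: 1-(pyridin-3-yl)-1H-1,2,3-triazol-4-yl in place of 4-(pyridin-3-yl)-1H-1,2,3-triazol-1-yl on a saturated chain carbon, seven bonds along the chain from an aromatic nitrogen. That change produced a 9.3-fold higher number from compound 1 to compound 2 (0.97 log units; beyond the scatter).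

Compound 3 `c1ccc(-c2ccccc2-n2cc(CCCCCCCn3cc(-c4cccnc4)nn3)nn2)cc1` gives 55.1 nM in this assay. Its core is built from the same atoms as that of compound 1, but joined differently; the difference between the two cores is not broken down here. The values of compound 3 and compound 2 lie within the scatter of each other, while compound 3 sits well above compound 1.

Compound 4 `c1ccc(-c2ccccc2-n2cc(CCCCCCCc3cn(-c4cccnc4)nn3)nn2)cc1` has not yet been measured. It stands to compound 3 as compound 2 stands to compound 1: 1-(pyridin-3-yl)-1H-1,2,3-triazol-4-yl in place of 4-(pyridin-3-yl)-1H-1,2,3-triazol-1-yl on a saturated chain carbon, seven bonds along the chain from an aromatic carbon. The two place lines are not identical, since in the pair of compound 1 and compound 2 the chain runs from an aromatic nitrogen and here it runs from an aromatic carbon, so this is the same kind of change rather than the same change. Resting on a single precedent, the step from compound 3 to compound 4 is expected to be a 7.3-fold higher number from compound 3 to compound 4 (0.86 log units; beyond the scatter), near the earlier one. Compound 4 is therefore estimated at 400 nM, with a range from 120 nM to 1500 nM in this assay.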

Compound 4, half-maximal effective concentration: > 500 nM
Compound 4: no number, only a limit; the forecaster's own chance of this, stated with the estimate: 5%; at least 1.2-fold (0.09 log units) between middle value and limit.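

Compound 4 gives > 500 nM in this assay as a limit of the assay and not a number. The step that can be drawn from it is an at least 9.0-fold higher number from compound 3 to compound 4 (0.95 log units; beyond the scatter), so on the core of compound 3, as on the core of compound 1, putting 1-(pyridin-3-yl)-1H-1,2,3-triazol-4-yl in place of 4-(pyridin-3-yl)-1H-1,2,3-triazol-1-yl goes with a higher number, beyond the scatter in both pairs. Among the compounds shown here, this shows that the direction of the change held on both cores, but it rests on only two pairs, and it does not show that the size of the step carried over, since the second step has only a lower bound: the same change on two cores in this assay, a 9.3-fold higher number (0.97 log units; beyond the scatter) from compound 1 to compound 2 and an at least 9.0-fold higher number (0.95 log units; beyond the scatter) from compound 3 to compound 4; the limit leaves it open whether they differ.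

All the compounds shown have the same chain and the same pyridin-3-yl ring, so they leave open whether the change would go the same way with a longer chain, or with a plain phenyl ring in place of the pyridin-3-yl ring. They also leave open how the change would behave on a core carrying an amine or a carboxylic acid.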